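This account rests on a few compounds, and the source may have more. Where it says the series, first, only, none or still open, it means among the compounds named here.

Working notes on the series. In a functional assay on SK-OV-3 cells (Homo sapiens) for inhibition, read by CCK-8 assay, with a stated time of 70 h (on this read-out higher numbers stand for weaker inhibition and lower numbers for stronger inhibition), compound 1 (`O=C(O)c1cccc(COc2ccc(OCCOCCNC3CCCC3)cc2)c1`) gives > 100000 nM, which is a limit of the assay and not a number. This puts compound 1 at the limit of > 100000 nM in this assay, at which 1 of the 2 values shown sits. Within the data shown here, the only numeric reading so far comes from compound 2 (`CC(C)(C)OC(=O)n1ccc(NCCOCCOc2ccc(OCc3ccccc3)cc2)c1`), which gives 13000 nM in this assay.

The next step leads to compound 3 (`Nc1cccc(COc2ccc(OCCOCCNC3CCCC3)cc2)c1`). The change is amino in place of carboxy on an aromatic carbon, meta to a large group, with the rest of the core of compound 1 unchanged.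

Among the measured compounds shown here, no measured pair isolates this change, so any expectation rests on little. A shift towards stronger inhibition in this assay is expected, though probably a moderate one, and a second reading at the assay limit remains a real possibility. The numeric reading of compound 2 at 13000 nM shows only that this assay can return a number for a compound of this series.

The expected change is an at least 2.5-fold lower number from compound 1 to compound 3 (0.39 log units; beyond the scatter).

For compound 3 the estimate is 40000 nM, with an expected range of 10000 nM to 100000 nM.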

Compound 3, half-maximal inhibitory concentration: 10800 nM
Compound 3: the middle estimate sits 3.7-fold (0.57 log units) above what was measured; the measured number falls inside the stated range.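

Among these compounds, replacing carboxy with amino on this aromatic carbon, meta to a large group, gives the first readable step: in this assay it amounts to an at least 9.2-fold lower number from compound 1 to compound 3 (0.96 log units; beyond the scatter). This shows that the group at this place can decide whether the core of compound 1 gives a numeric reading at all, as compound 3 gives 10800 nM with everything else unchanged. Compound 1 stands at a limit of the assay and not at a number, so the step fixes only a minimum size and its full size stays unknown: the limit of > 100000 nM in this assay, at which 1 of the 3 values shown sits.

The compounds shown leave open whether the step comes from losing carboxy or from gaining amino, a question that a plain hydrogen, a hydroxyl group or a methyl ester at the same place would bear on. Also open, from the compounds shown here alone, is how far the nitrogen itself matters, which an acetamide or a dimethylamino group on this carbon would address, and whether the same change from 3-carboxyphenyl to 3-aminophenyl gives a similar step on a core with a different amine at the end of its chain.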